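The source may report more compounds than this note shows. Statements on the series, on what has been measured and on what is new or still open speak of the compounds shown alone.

Compound 1 `O=c1n(C2CSC(CO)O2)ccc2nc(-c3ccc([N+](=O)[O-])cc3)cn12` stands only at a boundary of the numbers shown. In an ADME assay on HepG2 2.2.15 cells (Homo sapiens) for cytotoxicity, read by neutral red uptake (a lower number here means that less compound is tolerated, a higher number that more compound is tolerated), compound 1 gives > 26700 nM, which is a limit of the assay and not a number. Compound 2 `O=c1n(C2CSC(CO)O2)ccc2nc(CO)cn12` gives 456000 nM in this assay. Compound 3 `O=c1n([C@H]2CO[C@H](CO)O2)ccc2nc(-c3ccc([N+](=O)[O-])cc3)cn12` differs from compound 1 by a group of 7 heavy atoms (4 carbon, 3 oxygen; one five-membered non-aromatic ring with 2 hetero atoms) in place of a group of 7 heavy atoms (4 carbon, 2 oxygen, 1 sulfur; one five-membered non-aromatic ring with 2 hetero atoms), on an aromatic nitrogen. Going by the values given here, with one of the two values at the limit (the limit of > 26700 nM in this assay, at which 1 of the 2 values shown sits), no measured step anchors this exchange. The step that the limit leaves unreadable from compound 1 to compound 3 is expected to stay within the usual scatter, with compound 3 likely again reaching only a limit. Compound 3 is estimated at 100000 nM, between 26700 nM and 500000 nM.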

Compound 3, half-maximal cytotoxic concentration: 517000 nM
Compound 3: middle estimate off by 5.2-fold (0.71 log units), on the low side; measured number above the stated range.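

No step from compound 1 to compound 3 can be read, because the value of compound 1 is a limit and not a number: the limit of > 26700 nM in this assay, at which 1 of the 3 values shown sits.

The compounds shown leave open how much tolerated concentration changes when 2-(hydroxymethyl)-1,3-dioxolan-4-yl replaces the sulfur-containing ring.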